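The source may hold more compounds than are shown below. What is called first, only, known or untested is meant among the compounds shown, and "the series" means these compounds.

Compound 2, `COc1cc2c(Oc3ccc(NC(=O)c4nnn(-c5ccccc5Cl)c4C(F)(F)F)cc3F)ccnc2cc1OCCCN1CCN(C)CC1`, gives 330 nM in a functional assay on NCI-H460 cells (Homo sapiens) for cytotoxicity, read by MTT assay, with a stated time of 72 h; on this read-out lower numbers stand for stronger inhibition and higher numbers for weaker inhibition. Compound 1, `COc1cc2c(Oc3ccc(NC(=O)c4nnn(-c5ccc(C)cc5)c4C(F)(F)F)cc3F)ccnc2cc1OCCCN1CCCC1`, gives 790 nM in this assay.

Compound 2 stands as the lower of the two numbers; compound 1 shows a higher number, and the gap between them lies beyond the scatter. Compound 3, `COc1cc2c(Oc3ccc(NC(=O)c4nnn(-c5ccc(C)cc5)c4C(F)(F)F)cc3F)ccnc2cc1OCCCN1CCN(C)CC1`, differs from compound 2 by 4-methylphenyl in place of 2-chlorophenyl on an aromatic nitrogen. For the measured compounds named here, no step between measured compounds isolates this change, since compound 1 also carries a different tail, so the size of the step is open. A modest rise in the number, toward that of compound 1, is expected: the step from compound 2 to compound 3 in this assay is estimated as a 1.8-fold higher number from compound 2 to compound 3 (0.26 log units; within the scatter). Compound 3 is expected at 600 nM, in the range 250 nM to 1500 nM.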

Compound 3, half-maximal inhibitory concentration: 1240 nM
Compound 3: middle estimate off by 2.1-fold (0.32 log units), on the low side; the range from low to high includes it.
By their numbers in this assay, from the lowest: compound 2; then compounds 1 and 3 (each within the scatter of the next).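

In this assay, 4-methylphenyl in place of 2-chlorophenyl on the aromatic nitrogen gives a 3.8-fold higher number from compound 2 to compound 3 (0.57 log units; beyond the scatter) with the tail held constant, so the group at this position changes the read-out. With 4-methylphenyl held constant, 4-methylpiperazin-1-yl in place of pyrrolidin-1-yl gives a 1.6-fold higher number from compound 1 to compound 3 (0.20 log units; within the scatter) and so shows no step beyond the scatter. Nothing measured here explains either step. The compounds shown leave open whether a 4-chlorophenyl or 2-methylphenyl group would separate the choice of substituent from its ring position. They also leave open whether the aryl step holds with the pyrrolidin-1-yl tail.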